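A Small Ring Replaces a Short Chain on a Ring Nitrogen

The source may report more compounds than this note shows. Statements on the series, on what has been measured and on what is new or still open speak of the compounds shown alone.

Compound 1 `CC(C)CCn1nc(C(=O)N[C@H]2COc3ccccc3N(C)C2=S)nc1Cc1ccccc1` and compound 2 `COCCn1nc(C(=O)N[C@H]2COc3ccccc3N(C)C2=S)nc1Cc1ccccc1` share one core and differ only in the group carried on one aromatic nitrogen. In a toxicity assay on HT-29 cells (Homo sapiens) for cytotoxicity (on this read-out higher numbers stand for lower toxicity in this test and lower numbers for higher toxicity in this test), compound 1 gives > 100000 nM, which is a limit of the assay rather than a number. In this assay compound 2 gives > 100000 nM, again a limit rather than a number. Going by the values given here, the only measured step, a step that the two limits leave unreadable from compound 1 to compound 2, therefore cannot be read, since (the limit of > 100000 nM in this assay, at which 2 of the 2 values shown sit). Compound 3 `CN1C(=S)[C@@H](NC(=O)c2nc(Cc3ccccc3)n(C3COC3)n2)COc2ccccc21` has not yet been measured. Its change from compound 2, (oxetan-3-yl in place of 2-methoxyethyl on an aromatic nitrogen), keeps the heavy-atom count and the acceptor count unchanged while closing the chain into a small ring. Among the compounds with values here, no measured step speaks directly to this change; the one step available is itself unreadable, and both known values sit at the limit. The expectation for compound 3 is therefore a value at that same limit, with the step that the limit leaves unreadable from compound 2 to compound 3 expected to be none beyond the scatter. Compound 3 is estimated at 150000 nM, within a range from 60000 nM to 400000 nM.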

Compound 3, half-maximal cytotoxic concentration: > 100000 nM
Compound 3 was reported as a limit; the forecaster's own chance of this, stated with the estimate: 85%; the middle value is on the limit's open side.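

In this assay compound 3 gives a limit rather than a number, so neither its step from compound 2 nor its step from compound 1 can be read: the limit of > 100000 nM in this assay, at which 3 of the 3 values shown sit. The compounds shown leave open whether the group on the aromatic nitrogen changes toxicity in this test at all, with no number from any of the three to compare.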